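The compounds below may be only part of what the source reports. "The series", "measured", "known", "first", "only" and "open" are said of these compounds alone.

In an assay on Prostate gland for inhibition of steroid 5-alpha-reductase (Rattus norvegicus) (on this read-out lower numbers stand for stronger inhibition and higher numbers for weaker inhibition), compound 1 `C/C(=C\C(=O)Nc1ccccc1OCCCC(=O)O)c1ccc2c(ccn2C)c1` gives 780 nM. Compound 2 `CCCCCn1ccc2cc(/C(C)=C/C(=O)Nc3ccccc3OCCCC(=O)O)ccc21` gives 23 nM, and compound 3 `CCC(c1ccccc1)n1ccc2cc(/C(C)=C/C(=O)Nc3ccccc3OCCCC(=O)O)ccc21` gives 19 nM. The steps of a 34-fold lower number from compound 1 to compound 2 (1.53 log units; beyond the scatter) and a 41-fold lower number from compound 1 to compound 3 (1.61 log units; beyond the scatter) are both large, whereas a 1.2-fold lower number from compound 2 to compound 3 (0.08 log units; within the scatter) stays within the scatter. Compound 3 therefore has the lowest of the three numbers shown, though compound 2 lies within the scatter of it, and compound 1 sits far above. Compound 4 `C/C(=C\C(=O)Nc1ccccc1OCCCC(=O)O)c1ccc2c(ccn2C(c2ccccc2)c2cccnc2)c1` differs from compound 3 in one place: pyridin-3-yl in place of ethyl on a saturated chain carbon bound to an aromatic carbon and an aromatic nitrogen. Among the measured compounds shown here, no measured step introduces a pyridin-3-yl, so the only guide is the step from compound 2 to compound 3, which was within the scatter. A step of no more than the scatter is expected in this assay. Compound 4 is estimated at 22 nM, between 8 nM and 60 nM. That expectation means a 1.2-fold higher number from compound 3 to compound 4 (0.06 log units; within the scatter).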

Compound 4, half-maximal inhibitory concentration: 47 nM
Beside the measured number, compound 4's estimate is 2.1-fold (0.33 log units) below it, within the range that was stated.
By their numbers in this assay, from the lowest: compounds 3 and 2 (each within the scatter of the next); then compound 4; then compound 1.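

On the saturated chain carbon bound to an aromatic carbon and an aromatic nitrogen, pyridin-3-yl in place of ethyl gives a 2.5-fold higher number from compound 3 to compound 4 (0.39 log units; beyond the scatter) in this assay. The change is modest, but it shows that the group on this carbon can shift the number, which the step from pentyl to 1-phenylpropyl on the aromatic nitrogen did not show. Nothing available explains this rise. Still open, on these data alone, is whether the ring nitrogen matters, since a phenyl or a pyridin-4-yl in place of the pyridin-3-yl would be needed to test this.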